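Replacing the guanidine-bearing side chain with sec-butyl

The compounds below may be only part of what the source reports. "The series", "measured", "known", "first", "only" and "open" are said of these compounds alone.

In a functional assay on the whole organism (Tail, strain ICR) with Mus musculus as the target, in the tail flick test, with a stated time of 30 min, at a dose of 25 umol/kg by the oral route (a lower number here means a weaker effect, a higher number a stronger effect of the compound at the dose given), compound 1 `N=C(N)NCCC[C@H](NC(=O)CN(c1ncnc2c1ncn2C1CCCCO1)C1CC1)C(=O)OCc1ccccc1` gives 34.3%. Compound 2 `NCCCC[C@H](NC(=O)CN(c1nc(Cl)nc2[nH]cnc12)C1CC1)C(=O)OCc1ccccc1` gives 26.1%, which lies within the scatter of that number, whereas compound 3 `O=C(CN(c1nc(Cl)nc2[nH]cnc12)C1CC1)NCC(=O)OCc1ccccc1` gives 18.7%, a gap beyond the scatter. Compound 4 `CC[C@H](C)[C@H](NC(=O)CN(c1ncnc2c1ncn2C1CCCCO1)C1CC1)C(=O)OCc1ccccc1` differs from compound 1 in one place: a group of 4 heavy atoms (4 carbon; no ring) in place of a group of 7 heavy atoms (4 carbon, 3 nitrogen; no ring), on a saturated chain carbon bound to an amide-type nitrogen and a carbonyl carbon. For the measured compounds named here, the only measured step touching this position is a number 7.4 percentage points lower from compound 2 to compound 3 (within the scatter), where the side chain was lost entirely and the number moved within the scatter. A swap to a short branched chain is therefore expected to cost little, if anything, so a step of a number 7.3 percentage points lower from compound 1 to compound 4 (within the scatter) is estimated, not beyond the scatter. Compound 4 is expected to give 27%, between 14% and 40%.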

Compound 4, a percentage reported as activity, at one dose (the size of the read-out at that dose, not a potency): 25.6%
Compound 4: middle estimate off by 1.4 percentage points, on the high side, and the stated range covers the measured number.
By their numbers in this assay, from the lowest: compounds 3, 4, 2 and 1 (each within the scatter of the next, the first and the last beyond it).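

In this assay sec-butyl in place of the group of 7 heavy atoms gives a number 8.7 percentage points lower from compound 1 to compound 4 (within the scatter) and so, on the core of compound 1, nitrogen in this side chain is not needed to stay within the scatter. The earlier step at this position concerned loss of the whole chain on another core, whereas this one shows an all-carbon branched chain on the core of compound 1. No measurement available explains the result. Open, as far as these compounds go, is whether a carboxylic acid, an amine on a shorter chain or a longer alkyl chain at this position would move the number beyond the scatter. Also open, from the compounds shown here alone, is whether sec-butyl gives the same result on the core of compound 2.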